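This account rests on a few compounds, and the source may have more. Where it says the series, first, only, none or still open, it means among the compounds named here.

Compound 1 `CCCC(=O)OCc1ccc2oc(=O)c(C(=O)Oc3cccc(Br)c3)cc2c1` and compound 2 `CCCCCCC(=O)OCc1ccc2oc(=O)c(C(=O)Oc3cccc(Br)c3)cc2c1` share one core and differ only in the group on the carbonyl carbon of the ester. In a functional assay on HT-1080 cells (Homo sapiens), read by transwell migration, with a stated time of 24 h, tested at 1 uM (a lower number here means a stronger effect, a higher number a weaker effect of the compound at the concentration tested), compound 1 gives 50.5% and compound 2 gives 55.6%. The step of a number 5.1 percentage points higher from compound 1 to compound 2 (within the scatter) lies within the scatter. Compound 2 holds the higher of the two numbers, with compound 1 nearest and within the scatter. Compound 3 `CC(C)C(=O)OCc1ccc2oc(=O)c(C(=O)Oc3cccc(Br)c3)cc2c1` differs from compound 2 by isopropyl in place of hexyl on a carbonyl carbon. Among the compounds with values here, only the step of a number 5.1 percentage points higher from compound 1 to compound 2 (within the scatter) bears on this change, and it stayed within the scatter, so no step beyond the scatter is expected in this assay. Compound 3 is therefore expected at 52% (range 38% to 66%), an estimated step of a number 3.6 percentage points lower from compound 2 to compound 3 (within the scatter).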

Compound 3, a percentage reported as activity, at one concentration (the size of the read-out at that concentration, not a potency): 37.8%
Estimate against measurement, compound 3: 14.2 percentage points above, outside the stated range (below it).
By their numbers in this assay, from the lowest: compound 3; then compounds 1 and 2 (each within the scatter of the next).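

On the carbonyl carbon, isopropyl in place of hexyl gives a number 17.8 percentage points lower from compound 2 to compound 3 (beyond the scatter) in this assay and isopropyl in place of propyl gives a number 12.7 percentage points lower from compound 1 to compound 3 (beyond the scatter) in the same read-out, so this position does respond to the group it carries. Hexyl and propyl had not separated there, and among these three groups only isopropyl stands apart. Nothing at hand explains this difference.
The compounds shown leave open whether tert-butyl would follow isopropyl, and whether a phenyl ring or an amine on this carbonyl carbon would shift the read-out further.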